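The source may report more compounds than this note shows. Statements on the series, on what has been measured and on what is new or still open speak of the compounds shown alone.

Working notes on the series.

The shared core is carried unchanged through compound 1 `CN(C)C(=O)c1cc2cnc(Nc3ccc(C(=O)NCCCN=C=S)cc3)nc2n1C1CCCC1`, compound 2 `CN(C)C(=O)c1cc2cnc(Nc3ccc(C(=O)NCCCN=C=S)cc3F)nc2n1C1CCCC1` and compound 3 `CN(C)C(=O)c1cc2cnc(Nc3ccc(C(=O)NCCCCCCCN=C=S)cc3F)nc2n1C1CCCC1`. In a functional assay on A549 cells (Homo sapiens) for inhibition, read by CCK-8 assay, with a stated time of 72 h, tested at 1 uM (a lower number here means a weaker effect, a higher number a stronger effect of the compound at the concentration tested), compound 1 gives 32.9%, compound 2 gives 16.7% and compound 3 gives 0.05%. Compound 2 thus stands second highest of the three numbers: the step of a number 16.2 percentage points lower from compound 1 to compound 2 (beyond the scatter) sets it beyond the scatter from compound 1, and the step of a number 16.7 percentage points lower from compound 2 to compound 3 (beyond the scatter) sets it beyond the scatter from compound 3.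

Compound 4 `CN(C)C(=O)c1cc2cnc(Nc3ccc(C(=O)NCCCN=C=S)cc3O)nc2n1C1CCCC1` is the next candidate. Relative to compound 2 the change is hydroxy in place of fluoro on an aromatic carbon.

Of the two measured steps, the one that touches this aromatic position is a number 16.2 percentage points lower from compound 1 to compound 2 (beyond the scatter), where introducing fluoro there moved the read-out by a modest amount; the step of a number 16.7 percentage points lower from compound 2 to compound 3 (beyond the scatter) concerns the chain on the amide and does not bear directly. Among the measured compounds shown here, no measured pair exchanges fluoro for hydroxy, so the direction for compound 4 is open; a modest step in either direction, or none beyond the scatter, is equally plausible.

On that basis the estimate for compound 4 in this assay is 20%, between 4% and 38%, corresponding to an expected step of a number 3.3 percentage points higher from compound 2 to compound 4 (within the scatter).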

Compound 4, a percentage reported as inhibition, at one concentration (the size of the read-out at that concentration, not a potency): 55.9%
The estimate for compound 4 lay 35.9 percentage points below the measured number, outside the stated range (above it).
By their numbers in this assay, from the lowest: compound 3; then compound 2; then compound 1; then compound 4.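

The aromatic carbon ortho to a large group turns out to be more sensitive than the fluoro step alone suggested: in this assay, hydroxy in place of fluoro gives a number 39.2 percentage points higher from compound 2 to compound 4 (beyond the scatter), a large step. Measured against hydrogen, the substituents part in direction: fluoro gives a number 16.2 percentage points lower from compound 1 to compound 2 (beyond the scatter), whereas hydroxy gives a number 23 percentage points higher from compound 1 to compound 4 (beyond the scatter), so the earlier loss on substitution at this carbon does not extend to every group placed there. No measured property or other supporting observation accompanies the result, so the difference between hydroxy and fluoro stays an observation in this read-out alone.

On these data alone, whether a methoxy or an amine on this aromatic carbon would follow hydroxy, follow fluoro or behave differently from both remains open, and with it whether the hydrogen-bond donor counted on hydroxy has any connection with the higher number. Also open, as far as these compounds go, is whether hydroxy would give a similar step when paired with the longer chain of compound 3, since the hydroxy result is available only with the shorter chain.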